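Phenyl on the Sulfur of a Weak Binder

This account rests on a few compounds, and the source may have more. Where it says the series, first, only, none or still open, it means among the compounds named here.

Among the measured compounds shown here, compound 3 `C=C[C@@H]1OC(c2ccc(Br)cc2)=N[C@H]1S` is one of three compounds measured in an assay on isolated protein for inhibition of matrix metalloproteinase-9 (Homo sapiens); on this read-out higher numbers stand for weaker inhibition and lower numbers for stronger inhibition. In this assay compound 3 gives > 100000 nM, which is a limit of the assay rather than a number. Compound 1 `C=C[C@@H]1OC(c2ccc(Cl)cc2)=N[C@H]1S` stands in the same place: in this assay compound 1 gives > 100000 nM, again a limit. The step that the two limits leave unreadable from compound 1 to compound 3 therefore has no readable size, because the limit of > 100000 nM in this assay, at which 2 of the 3 values shown sit, covers both ends of it. Compound 2 `C=C[C@@H]1OC(/C=C/c2ccc(Br)cc2)=N[C@H]1CO` differs from the others in more than one place; in this assay compound 2 gives 22000 nM.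

Compound 4 `C=C[C@@H]1OC(c2ccc(Br)cc2)=N[C@H]1Sc1ccccc1` has not yet been measured. It differs from compound 3 by phenyl in place of hydrogen on a sulfur. For the measured compounds named here, no measured step touches the sulfur, and the one measured step gives no readable size, so the data give neither a direction nor a size for this change. Compound 3 sits at a limit of the assay. Compound 4 is therefore expected to remain weak, and the estimate for compound 4 in this assay is 60000 nM, between 5000 nM and 300000 nM. That estimate means a step of an at least 1.6-fold lower number from compound 3 to compound 4 (0.22 log units; that floor lies within the scatter), with a wide uncertainty.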

Compound 4, inhibition constant: 94000 nM
Estimate against measurement, compound 4: 1.6-fold (0.19 log units) below, within the range that was stated.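

Phenyl on the sulfur gives the first step at this position with a readable floor: an at least 1.0-fold lower number from compound 3 to compound 4 (0.02 log units; that floor lies within the scatter). Of the two compounds, only compound 4 has a real number in this assay, so the sulfur can carry this aromatic ring without the compound staying at the limit. On these data alone, the floor still allows for no real change at all, and the true size of the step stays unknown because compound 3 has only a limit and not a number: the limit of > 100000 nM in this assay, at which 2 of the 4 values shown sit.

As far as these compounds go, whether a benzyl, a carboxylic acid or an amine on the sulfur would lower the number further stays open. From the compounds shown here alone, it is also open whether chloro in place of bromo on the aromatic ring would make a readable difference once the sulfur carries phenyl.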